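The source may report more compounds than this note shows. Statements on the series, on what has been measured and on what is new or still open speak of the compounds shown alone.

Measured so far:
Compound 1, `ClCc1ccc(Cn2cnc3c(Cl)ncnc32)cc1`: 12600 nM
Compound 2, `Nc1nc(Cl)c2ncn(Cc3ccc(CCl)cc3)c2n1`: 20000 nM
Compound 3, `ClCc1ccccc1Cn1cnc2c(Cl)ncnc21`: 4670 nM

All three compounds were tested in a functional assay on HCT-15 cells (Homo sapiens) for cytotoxicity, read by sulforhodamine B assay, with a stated time of 48 h; on this read-out lower numbers stand for stronger inhibition of growth and higher numbers for weaker inhibition of growth. Compound 1 and compound 3 are built from the same atoms joined differently; the difference between the two cores is not broken down here. In this assay compound 3 gives the lowest of the three numbers, with compound 1 the nearest and compound 2 the furthest, both gaps lying beyond the scatter.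

One structural change appears twice among these compounds. Between compound 1 and compound 2 it is amino in place of hydrogen on an aromatic carbon, and on this read-out it made a 1.6-fold higher number from compound 1 to compound 2 (0.20 log units; within the scatter). Compound 4, `Nc1nc(Cl)c2ncn(Cc3ccccc3CCl)c2n1`, has not yet been measured. It stands to compound 3 as compound 2 stands to compound 1: the change is amino in place of hydrogen on an aromatic carbon, the same change, since the surroundings of the place are described in the same words in both pairs.

The expectation for compound 4 rests on that one earlier step. Because the step from compound 1 to compound 2 was a 1.6-fold higher number from compound 1 to compound 2 (0.20 log units; within the scatter), compound 4 is expected to give a number slightly above that of compound 3, a step of about a 1.5-fold higher number from compound 3 to compound 4 (0.18 log units; within the scatter). Compound 4 is therefore estimated at 7000 nM in this assay, with a likely range from 3500 nM to 15000 nM.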

Compound 4, concentration for total growth inhibition: 7410 nM
Estimate against measurement, compound 4: 1.1-fold (0.02 log units) below, within the range that was stated.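

In this assay, amino in place of hydrogen on an aromatic carbon gave a 1.6-fold higher number from compound 3 to compound 4 (0.20 log units; within the scatter), and set beside the earlier step on the other core, the two steps agree: the same change on two cores in this assay, a 1.6-fold higher number (0.20 log units; within the scatter) from compound 1 to compound 2 and a 1.6-fold higher number (0.20 log units; within the scatter) from compound 3 to compound 4, 1.0-fold (0.00 log units) apart, within the scatter of two such steps. Across these two cores, then, the change carried over with no difference that can be detected, and on both cores the amino compound stays within the scatter of its parent, so the pairs do not show that the amino group moves the number at all. Among the compounds shown here, the agreement rests on only two pairs, read in one cell line with one read-out, and it does not show that the change would behave in the same way on any further core or in any other test.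

The compounds shown leave open what a group other than amino would do at this place on the ring, such as a methylamino group, a hydroxyl or a methyl. They also leave open whether a methoxy group in place of the chloro group, or a hydroxymethyl or plain methyl group in place of the chloromethyl group, would give numbers like these.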